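Moving the Chlorine on the Piperazine Aryl Group

The compounds below may be only part of what the source reports. "The series", "measured", "known", "first", "only" and "open" are said of these compounds alone.

Measured so far:
compound 1, `O=C(CN1CCN(c2ccc([N+](=O)[O-])cc2)CC1)N1CCN(c2nnc(-c3ccccc3)c(-c3ccccc3)n2)CC1`, > 886000 nM
compound 2, `Cc1ccc(-c2nnc(N3CCN(C(=O)CN4CCN(c5ccccc5Cl)CC4)CC3)nc2-c2ccc(C)cc2)cc1`, 859000 nM

In a functional assay on MCF7 cells (Homo sapiens) for cytotoxicity, read by MTT assay, with a stated time of 24 h (a lower number here means a stronger inhibitor, a higher number a weaker inhibitor), compound 2 gives 859000 nM. For compound 1 the result is a limit of the assay, > 886000 nM. The entry the limit of > 886000 nM in this assay, at which 1 of the 2 values shown sits, records that one of the two values sits at that limit. Going by the values given here, compound 2 therefore provides the only actual number, and the data set no order between the two compounds.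

Compound 3, `Cc1ccc(-c2nnc(N3CCN(C(=O)CN4CCN(c5ccc(Cl)cc5)CC4)CC3)nc2-c2ccc(C)cc2)cc1`, is not yet measured. It differs from compound 2 by 4-chlorophenyl in place of 2-chlorophenyl on an amine nitrogen in a ring. Among the compounds with values here, no step between measured compounds is available to anchor this change. The expected step is a 1.0-fold lower number from compound 2 to compound 3 (0.00 log units; within the scatter), which is taken to be none beyond the usual scatter, with no direction favoured. Compound 3 is accordingly estimated to give 850000 nM, with an expected range from 400000 nM to 1800000 nM.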

Compound 3, half-maximal inhibitory concentration: 660000 nM
Beside the measured number, compound 3's estimate is 1.3-fold (0.11 log units) above it; low and high end bracket the measured number.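

In this assay, placing 4-chlorophenyl in place of 2-chlorophenyl on the amine nitrogen of the ring gives a 1.3-fold lower number from compound 2 to compound 3 (0.11 log units; within the scatter). Going by these compounds alone, this is the first step that can be read at this position, and it shows that, with the rest of the molecule unchanged, moving the chlorine around this aryl group leaves the result within the scatter. Compound 1 differs from the other two in more than one place, so no step to it can be read, and its entry is a limit of the assay: the limit of > 886000 nM in this assay, at which 1 of the 3 values shown sits.

The compounds shown leave open whether a group other than chlorine on this aryl ring, such as a methoxy group or a carboxylic acid, would move the number beyond the scatter. They also leave open whether a benzyl group or a pyridine ring at this amine nitrogen would do so.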